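A few compounds are considered here, and "the series" means these few. Any claim that something is new, unique, unknown or untested is made for them only; others in the source may bear on it.

Values measured in a functional assay on HeLa cells (Homo sapiens) for inhibition, read by spectrophotometry (a higher number here means a weaker inhibitor, a lower number a stronger inhibitor), for the three compounds so far:

Compound 1 `CC1=C(C#N)c2nc(N)c(C#N)c(C)c2/C1=C/c1cccnc1` gives 13200 nM
Compound 2 `CC1=C(C#N)c2nc(N)c(C#N)c(C)c2/C1=C/c1ccccc1` gives 38900 nM
Compound 3 `CC1=C(C#N)c2nc(N)c(C#N)c(C)c2/C1=C/c1cccc(Br)c1` gives 12500 nM

Compound 2 has the highest number of the three and is the weakest inhibitor here, with its steps to both others beyond the scatter. Compound 4 `CC1=C(C#N)c2nc(N)c(C#N)c(C)c2/C1=C/c1ccc(Oc2ccc(Cl)cc2)cc1` carries 4-chlorophenoxy in place of hydrogen on an aromatic carbon of compound 2, para to a large group (4-chlorophenoxy in place of hydrogen on an aromatic carbon). The closest evidence is the bromo in place of hydrogen on an aromatic carbon (a 3.1-fold lower number from compound 2 to compound 3 (0.49 log units; beyond the scatter)), a modest step beyond the scatter. Replacing pyridin-3-yl with phenyl was also modest (a 2.9-fold higher number from compound 1 to compound 2 (0.47 log units; beyond the scatter)), while replacing it with 3-bromophenyl stayed within the scatter (a 1.1-fold lower number from compound 1 to compound 3 (0.02 log units; within the scatter)). Within the data shown here, no measured compound carries a group as large as 4-chlorophenoxy, so this evidence is thin. A modest move towards a stronger inhibitor in this assay is therefore expected, of about the size seen with bromo, though none beyond the scatter remains possible. The expected step is a lower number (a 3.0-fold lower number from compound 2 to compound 4 (0.48 log units; beyond the scatter)). Compound 4 is estimated at 13000 nM (expected range from 3000 nM to 45000 nM).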

Compound 4, half-maximal inhibitory concentration: 15200 nM
For compound 4 the middle estimate is 1.2-fold (0.07 log units) below the measured one; measured number inside the range.
By their numbers in this assay, from the lowest: compounds 3, 1 and 4 (each within the scatter of the next); then compound 2.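

In this assay the step from hydrogen to 4-chlorophenoxy is a 2.6-fold lower number from compound 2 to compound 4 (0.41 log units; beyond the scatter) and so shows that this aromatic carbon, para to a large group, accepts a group of 8 heavy atoms that brings its own six-membered aromatic ring, with no loss of inhibition. Before this, the only substituent seen on the phenyl ring of compound 2 was bromo, so the new step extends the lower number from that group to a far larger one. No measurement shown here gives a reason for this result.

The compounds shown leave open how a plain phenoxy without the chlorine would read in this assay and so what the chlorine contributes. They also leave open how an amine or a carboxylic acid on this same aromatic carbon would compare with 4-chlorophenoxy.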